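A few compounds are considered here, and "the series" means these few. Any claim that something is new, unique, unknown or untested is made for them only; others in the source may bear on it.

In an ADME assay on HUVEC cells (Homo sapiens) for cytotoxicity, read by MTT assay, with a stated time of 48 h (on this read-out higher numbers stand for weaker inhibition and lower numbers for stronger inhibition), compound 1 `Cc1ccc2nc(Cl)c(/C=N/n3cc(-c4ccc(Cl)cc4)nc3N)cc2c1` gives 38500 nM. Compound 2 `Nc1nc(-c2cccc3ccccc23)cn1/N=C/c1cc2ccccc2nc1Cl` reaches only the limit of this assay, at > 50000 nM; of the two values shown, one sits at such a limit (the limit of > 50000 nM in this assay, at which 1 of the 2 values shown sits). Compound 3 `Cc1ccc2nc(Cl)c(/C=N/n3cc(-c4cccc5ccccc45)nc3N)cc2c1` differs from compound 2 by methyl in place of hydrogen on an aromatic carbon. For the measured compounds named here, no measured step matches this change, and the step is therefore expected to be about the size of the scatter, or no larger than it a number no higher from compound 2 to compound 3 (the limit leaves the size open). Compound 3 is thus expected to show weak inhibition near 50000 nM, somewhere between 25000 nM and 100000 nM.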

Compound 3, half-maximal inhibitory concentration: 9580 nM
Beside the measured number, compound 3's estimate is 5.2-fold (0.72 log units) above it, outside the stated range (below it).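

In this assay, methyl in place of hydrogen on this aromatic carbon gives an at least 5.2-fold lower number from compound 2 to compound 3 (0.71 log units; beyond the scatter), so a single added carbon at this position can shift the read-out beyond the scatter. With that methyl present in both compounds, naphthalen-1-yl in place of 4-chlorophenyl gives a 4.0-fold lower number from compound 1 to compound 3 (0.60 log units; beyond the scatter), so a second place in the molecule also moves the number. Compound 2 stands at a limit, so the full size of its step stays unknown: the limit of > 50000 nM in this assay, at which 1 of the 3 values shown sits.

As far as these compounds go, whether an ethyl, a methoxy or a fluorine on this carbon would act like methyl remains open. So does whether methyl has the same effect when 4-chlorophenyl replaces naphthalen-1-yl.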